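This account rests on a few compounds, and the source may have more. Where it says the series, first, only, none or still open, it means among the compounds named here.

Measured compounds:
- compound 1, `Oc1ccc(-c2cc(-c3ccccc3F)cc(-c3ccccc3O)n2)cc1`: > 50000 nM in a functional assay on HCT-15 cells (Homo sapiens) for inhibition; on this read-out lower numbers stand for stronger inhibition and higher numbers for weaker inhibition
- compound 2, `Oc1ccccc1-c1cc(-c2ccccc2C(F)(F)F)cc(-c2ccccc2O)n1`: 3970 nM

On the numbers shown, compound 2 is the only compound with a measured value in this assay. Compound 1 reaches only a limit in this assay, > 50000 nM; this is the limit at which (the limit of > 50000 nM in this assay, at which 1 of the 2 values shown sits). Compound 1 and compound 2 differ in two places, so their two values show only that one sits at the limit and the other does not.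

Compound 3, `Oc1ccc(-c2cc(-c3ccccc3C(F)(F)F)cc(-c3ccccc3O)n2)cc1`, is not yet measured. It follows from compound 2 by 4-hydroxyphenyl in place of 2-hydroxyphenyl on an aromatic carbon. For the measured compounds named here, no single-change step between measured compounds exists, so the size of this step in this assay is not known from data. Given that compound 1, which also carries a 4-hydroxyphenyl group, sits at the limit > 50000 nM, the expectation for the step from compound 2 to compound 3 is a loss beyond the scatter, a 3.8-fold higher number from compound 2 to compound 3 (0.58 log units; beyond the scatter). Compound 3 is therefore estimated at 15000 nM, within a range of 4000 nM to 50000 nM.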

Compound 3, half-maximal inhibitory concentration: 8990 nM
Estimate against measurement, compound 3: 1.7-fold (0.22 log units) above, within the range that was stated.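

With 4-hydroxyphenyl in place of 2-hydroxyphenyl on the aromatic carbon next to the ring nitrogen, this assay gives a 2.3-fold higher number from compound 2 to compound 3 (0.35 log units; beyond the scatter), the first measured size for this change, and a modest one. With 4-hydroxyphenyl held fixed, trifluoromethyl in place of fluoro gives an at least 5.5-fold lower number from compound 1 to compound 3 (0.74 log units; beyond the scatter), so the group on the other aryl ring changes the read-out by more than the hydroxyl shift does at this position, at least in this pair. Compound 1 stands at a limit of the assay, not at a number, so the full size of that second step stays open: the limit of > 50000 nM in this assay, at which 1 of the 3 values shown sits.

From the compounds shown here alone, how a methoxyphenyl or an aminophenyl group would read at this position remains open. Also open, going by these compounds, is whether the hydroxyl shift keeps its size with fluoro in place of trifluoromethyl.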